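The source may report more compounds than this note shows. Statements on the series, on what has been measured and on what is new or still open speak of the compounds shown alone.

Within the data shown here, in a functional assay on KB cells (Homo sapiens) for inhibition, read by sulforhodamine B assay, with a stated time of 72 h (on this read-out higher numbers stand for weaker inhibition of growth and lower numbers for stronger inhibition of growth), compound 2 `COC(=O)/C=C/c1ccncc1-c1ccc2ccccc2c1` gives 6730 nM, the only plain number among the values shown. The other member of the pair is compound 1 `NC(=O)/C=C/c1ccncc1-c1ccc2ccccc2c1`. In this assay compound 1 gives > 10000 nM, which is a limit of the assay rather than a number (the limit of > 10000 nM in this assay, at which 1 of the 2 values shown sits). Among the measured compounds shown here, the one measured step, an at least 1.4-fold lower number from compound 1 to compound 2 (0.17 log units; that floor lies within the scatter), comes from methoxy in place of amino on a carbonyl carbon. Compound 3 `NNC(=O)CCc1ccncc1-c1ccc2ccccc2c1` is not yet measured; its change from compound 2 is 2-(aminocarbamoyl)ethyl in place of 2-(methoxycarbonyl)ethenyl on an aromatic carbon. The step from compound 1 to compound 2 rests on methoxy in place of amino on a carbonyl carbon. Compound 3 instead carries 2-(aminocarbamoyl)ethyl in place of 2-(methoxycarbonyl)ethenyl. Compound 3 is therefore expected to land near the weak end, with a change of a 2.2-fold higher number from compound 2 to compound 3 (0.35 log units; beyond the scatter) toward weaker inhibition, estimated at 15000 nM and ranging from 5000 nM to 40000 nM.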

Compound 3, concentration for 50% growth inhibition: > 10000 nM
Compound 3 ended at the assay's limit; the forecaster's own chance of this, stated with the estimate: 55%; the middle value is on the limit's open side.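

In this assay compound 3 gives > 10000 nM, which is a limit of the assay and not a number. Placing 2-(aminocarbamoyl)ethyl instead of 2-(methoxycarbonyl)ethenyl on this aromatic carbon, opposite the ring nitrogen, gives an at least 1.4-fold higher number from compound 2 to compound 3 (0.17 log units; that floor lies within the scatter), so this change shows no clear shift in growth inhibition. The step between compound 1 and compound 3 cannot be read, and a second end group carrying nitrogen on the carbonyl now stands at the limit: the limit of > 10000 nM in this assay, at which 2 of the 3 values shown sit.

This single change replaces both the chain and its end group, so the compounds shown cannot separate the loss of the chain's double bond from the change at the carbonyl. As far as these compounds go, it also remains open how a 2-(methoxycarbonyl)ethyl chain, a carboxylic acid or a longer chain would behave at this position.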